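The compounds below may be only part of what the source reports. "The series", "measured", "known", "first", "only" and "open" are said of these compounds alone.

Of the compounds shown here, three have been measured in a functional assay on BV-2 cells (Mus musculus) for inhibition, read by Griess assay, with stated times of 3 h and 24 h; on this read-out higher numbers stand for weaker inhibition and lower numbers for stronger inhibition. Compound 1 `O=S(=O)(/C=C/c1ccc(O)c(O)c1)NCCCc1ccccc1` gives 17500 nM. Compound 2 `O=S(=O)(/C=C/c1ccc(O)c(O)c1)NCCCCc1ccccc1` gives 23800 nM. Compound 3 `CC(=O)Oc1ccc(/C=C/S(=O)(=O)NCCCc2ccccc2)cc1OC(C)=O` gives 15600 nM.

Compound 2 differs from compound 1 by benzyl in place of phenyl on a saturated chain carbon, three bonds along the chain from a sulfonamide nitrogen, and that change gave a 1.4-fold higher number from compound 1 to compound 2 (0.13 log units; within the scatter). Compound 4 `CC(=O)Oc1ccc(/C=C/S(=O)(=O)NCCCCc2ccccc2)cc1OC(C)=O` carries the same change relative to compound 3: benzyl in place of phenyl on a saturated chain carbon, three bonds along the chain from a sulfonamide nitrogen. The two places read the same word for word, so this is the same change on a different core; the difference between the core of compound 1 and the core of compound 3 is not broken down here.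

For compound 4 in this assay the expected step is a 1.3-fold higher number from compound 3 to compound 4 (0.13 log units; within the scatter), resting on the step of a 1.4-fold higher number from compound 1 to compound 2 (0.13 log units; within the scatter) observed for the same change, with nothing to show the core of compound 3 behaves differently. Compound 4 is therefore estimated at 21000 nM, between 11000 nM and 40000 nM.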

Compound 4, half-maximal inhibitory concentration: 20800 nM
Compound 4: the middle estimate sits 1.0-fold (0.00 log units) above what was measured; the measured number falls inside the stated range.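

Replacing the 3-phenylpropyl chain with the 4-phenylbutyl chain gave a 1.3-fold higher number from compound 3 to compound 4 (0.12 log units; within the scatter) in this assay. Set beside the earlier step, the same change reads alike on the two cores: the same change on two cores in this assay, a 1.4-fold higher number (0.13 log units; within the scatter) from compound 1 to compound 2 and a 1.3-fold higher number (0.12 log units; within the scatter) from compound 3 to compound 4, 1.0-fold (0.01 log units) apart, within the scatter of two such steps. Among the compounds shown here, neither step lies beyond the scatter, so this shows only that the change moved the number by no more than the scatter on either core; it rests on a single pair of cores and does not show that a change with a larger effect would carry over in the same way.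

The compounds shown leave open how a shorter chain or a chain longer than 4-phenylbutyl would read in this assay. They also leave open what an amine or a carboxylic acid in place of the phenyl would do.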